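A few compounds are considered here, and "the series" means these few. Any claim that something is new, unique, unknown or untested is made for them only; others in the source may bear on it.

Measured so far in a functional assay on HCT-15 cells (Homo sapiens) for inhibition, read by sulforhodamine B assay, with a stated time of 48 h, tested at 10 uM; a lower number here means less inhibition, a higher number more inhibition at the concentration tested (going by the name of the read-out):
compound 1, `c1ccc(-c2cn3ccnc3c(-c3ccc4ncn(C5CCCCC5)c4c3)n2)cc1`, 51.6%
compound 2, `Fc1ccc(-c2cn3ccnc3c(-c3ccc4ncn(C5CCCCC5)c4c3)n2)cc1`, 7.59%
compound 3, `c1cn2cc(-c3ccsc3)nc(-c3ccc4ncn(C5CCCCC5)c4c3)c2n1`, 1.37%

Compound 3 gives the lowest of the three numbers in this assay. Its gap to compound 2, a number 6.2 percentage points lower from compound 2 to compound 3 (within the scatter), is within the scatter, whereas the gap from compound 1, a number 50.2 percentage points lower from compound 1 to compound 3 (beyond the scatter), is large.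

Compound 4, `Brc1ccc(-c2cn3ccnc3c(-c3ccc4ncn(C5CCCCC5)c4c3)n2)cc1`, differs from compound 3 by 4-bromophenyl in place of thiophen-3-yl on an aromatic carbon. The step that bears on this is the halogen step on the phenyl, a number 44 percentage points lower from compound 1 to compound 2 (beyond the scatter), a large loss of inhibition. Compound 2 already carries a halogenated phenyl and sits within the scatter of compound 3, so a bromine in place of that fluorine gives no reason to expect a large change. Among the compounds with values here, no bromo compound has been measured, so the estimate is widened upward. Compound 4 is expected to give 10%, in the range 0% to 30%. The expected step is a number 8.6 percentage points higher from compound 3 to compound 4 (within the scatter), within the scatter.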

Compound 4, a percentage reported as inhibition, at one concentration (the size of the read-out at that concentration, not a potency): 35.8%
For compound 4 the middle estimate is 25.8 percentage points below the measured one, outside the stated range (above it).
By their numbers in this assay, from the lowest: compounds 3 and 2 (each within the scatter of the next); then compound 4; then compound 1.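

At this carbon of the shared core, the halogen on the phenyl matters in this assay: a number 28.2 percentage points higher from compound 2 to compound 4 (beyond the scatter), so the fluoro result does not carry over to bromo. Bromo still does not restore the unsubstituted phenyl, a number 15.8 percentage points lower from compound 1 to compound 4 (beyond the scatter), and the change from the thiophene gives a number 34.4 percentage points higher from compound 3 to compound 4 (beyond the scatter), so the halogenated phenyls do not form one group relative to thiophen-3-yl. Nothing available explains this order of hydrogen, fluoro and bromo.

From the compounds shown here alone, whether chloro, an amine or a carboxylic acid on the phenyl would track with compound 2 or compound 4 remains open.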